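A few compounds are considered here, and "the series" means these few. Any claim that something is new, unique, unknown or untested is made for them only; others in the source may bear on it.

Measured in a functional assay on NCI-H1993 cells (Homo sapiens) for inhibition, read by CCK-8 assay, with a stated time of 72 h; on this read-out higher numbers stand for weaker inhibition and lower numbers for stronger inhibition:
compound 1 `CC(c1cc2cccnc2cc1F)n1cnc2ncc(-c3cn[nH]c3)nc21`, 187 nM
compound 2 `CC(c1cc2cccnc2cc1F)n1cnc2ncc(-c3cnn(CCO)c3)nc21`, 175 nM
compound 3 `c1cnc2ccc(Cn3cnc4ncc(-c5cn[nH]c5)nc43)cc2c1`, 2890 nM

Compound 1 and compound 2 share one core; compound 3 carries another, and the difference between the two cores is not broken down here. Compound 2 differs from compound 1 by 2-hydroxyethyl in place of hydrogen on an aromatic nitrogen, and a 1.1-fold lower number from compound 1 to compound 2 (0.03 log units; within the scatter). Compound 3 stands highest of the three numbers: against compound 1 and against compound 2 its number is higher beyond the scatter, so the change of core is where the series moves.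

Compound 4 `OCCn1cc(-c2cnc3ncn(Cc4ccc5ncccc5c4)c3n2)cn1` is not yet measured. It differs from compound 3 by 2-hydroxyethyl in place of hydrogen on an aromatic nitrogen, the same change as that from compound 1 to compound 2. For compound 4 in this assay the step of a 1.1-fold lower number from compound 3 to compound 4 (0.05 log units; within the scatter) is expected, because a 1.1-fold lower number from compound 1 to compound 2 (0.03 log units; within the scatter) left the number essentially where it stood. On that basis compound 4 is estimated at 2600 nM, with a range from 1200 nM to 5500 nM. Whether the change behaves alike on the core of compound 3 rests on a single precedent, so the range is kept wide.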

Compound 4, half-maximal inhibitory concentration: 2330 nM
For compound 4 the middle estimate is 1.1-fold (0.05 log units) above the measured one; measured number inside the range.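

In this assay the change from hydrogen to 2-hydroxyethyl on the aromatic nitrogen gives a 1.2-fold lower number from compound 3 to compound 4 (0.09 log units; within the scatter) and so behaves on the core of compound 3 as it did on the core of compound 1, the two steps agreeing: the same change on two cores in this assay, a 1.1-fold lower number (0.03 log units; within the scatter) from compound 1 to compound 2 and a 1.2-fold lower number (0.09 log units; within the scatter) from compound 3 to compound 4, 1.2-fold (0.06 log units) apart, within the scatter of two such steps. Within this cell assay, the change is therefore tolerated on both cores and can be carried from one to the other without moving the number. Going by these compounds alone, this does not show that it would stay silent on any further core, since only two pairs support it, and neither step offers a gain or explains why the number holds.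

The compounds shown carry only hydrogen or 2-hydroxyethyl on that nitrogen, so it remains open whether a longer chain, an amine such as 2-aminoethyl or a carboxylic acid would also leave the number in place. Also open is which part of the difference between the two cores accounts for the higher numbers of compound 3 and compound 4.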